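The source may hold more compounds than are shown below. What is called first, only, known or untested is meant among the compounds shown, and "the series" means these compounds.

Working notes on the series. Compound 1 `Clc1ccc(COc2cc3n(n2)CCCC3)nc1` gives 1550 nM in a functional assay on HEK293 cells for negative allosteric modulation of metabotropic glutamate receptor 5 (Rattus norvegicus), read by FLIPR and calcium flux, with a stated time of 170 s; on this read-out higher numbers stand for weaker inhibition and lower numbers for stronger inhibition; compound 2 `O=C(Cc1ccccn1)c1cc2n(n1)CCCC2` gives 390 nM; compound 3 `N#Cc1ccc(CC(=O)c2cc3n(n2)CCCC3)nc1` gives 53 nM. Among the three measured compounds, compound 3 carries the lowest number: compound 2 stands nearest, and compound 1 furthest, with both gaps reaching beyond the scatter. Among the compounds with values here, the one single-point step available, a 7.4-fold lower number from compound 2 to compound 3 (0.87 log units; beyond the scatter), concerns the pyridine side of the molecule.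

Compound 4 `N#Cc1ccc(CC(=O)c2nn3c(c2C(F)(F)F)CCCC3)nc1` differs from compound 3 by trifluoromethyl in place of hydrogen on an aromatic carbon. Within the data shown here, no measured step touches the shared core itself, so the change from compound 3 to compound 4 has no direct precedent in these data; the step from compound 2 to compound 3 tells only that the series responds strongly to changes elsewhere. In the absence of a bearing step, the expectation for compound 4 is a number close to that of compound 3, with wide uncertainty in either direction, giving an expected 1.7-fold higher number from compound 3 to compound 4 (0.23 log units; within the scatter). The estimate for compound 4 in this assay is therefore 90 nM, with a range from 20 nM to 450 nM.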

Compound 4, half-maximal inhibitory concentration: 7180 nM
Compound 4: middle estimate off by 80-fold (1.90 log units), on the low side; the whole stated range lies below it.
By their numbers in this assay, from the lowest: compound 3; then compound 2; then compound 1; then compound 4.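

Within the data shown here, until this point no step touched the shared core, and the step of a 140-fold higher number from compound 3 to compound 4 (2.13 log units; beyond the scatter) in this assay shows that this aromatic carbon of the five-membered aromatic ring with 2 nitrogen does not tolerate every replacement of its hydrogen. The change also outweighs the earlier gain on the pyridine side, where cyano gave a 7.4-fold lower number from compound 2 to compound 3 (0.87 log units; beyond the scatter) in the same read-out, so trifluoromethyl at this one carbon removes more than cyano added. Nothing measured here bears on why the step is so large.

As far as these compounds go, whether the loss belongs to trifluoromethyl itself or to any group at this carbon stays open, and a fluorine atom or a methyl group here would help separate the two. Also open, from the compounds shown here alone, is how an amine or a hydroxyl group would behave at the same carbon.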